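The source may report more compounds than this note shows. Statements on the series, on what has been measured and on what is new or still open speak of the compounds shown alone.

Measured compounds:
- Compound 1 (`C[C@@H](O)[C@H]1C(=O)N2C(C(=O)OCC(F)(F)F)=C(S[C@@H]3CN[C@H](C(=O)Nc4cccc(C(=O)O)c4)C3)[C@H](C)[C@H]12`). In an ADME assay for metabolic stability, read by LC-MS, with a stated time of 3 h, at pH 6.5, tested at 50 uM (on this read-out higher numbers stand for a more stable compound and lower numbers for a less stable compound), compound 1 gives the limit value > 95%.
- Compound 2 (`CC(C)OC(=O)c1cccc(NC(=O)[C@@H]2C[C@H](SC3=C(C(=O)O)N4C(=O)[C@H]([C@@H](C)O)[C@H]4[C@H]3C)CN2)c1`). In this assay compound 2 gives the limit value > 95%.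
- Compound 3 (`C[C@@H](O)[C@H]1C(=O)N2C(C(=O)O)=C(S[C@@H]3CN[C@H](C(=O)Nc4cccc(C(=O)OCC(F)(F)F)c4)C3)[C@H](C)[C@H]12`). In this assay compound 3 gives the limit value > 95%.

Compound 3 thus stands at the limit of this assay, as do the other two values shown (the limit of > 95% in this assay, at which 3 of the 3 values shown sit). Going by the values given here, the one single-point step, a step that the two limits leave unreadable from compound 2 to compound 3, cannot be sized because both ends sit at that limit. Compound 4 (`C[C@@H](O)[C@H]1C(=O)N2C(C(=O)OCC(F)(F)F)=C(S[C@@H]3CN[C@H](C(=O)Nc4cccc(C(=O)OCC(F)(F)F)c4)C3)[C@H](C)[C@H]12`) differs from compound 3 by 2,2,2-trifluoroethyl in place of hydrogen on an oxygen next to a carbonyl group. No readable measured step bears on this change; every value in this assay is a limit. The step is therefore expected to be none beyond the scatter, i.e. a number no higher from compound 3 to compound 4 (the limit leaves the size open), with compound 4 again expected at the limit. Compound 4 is estimated at 95%, range 85% to 100%.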

Compound 4, percent of the compound remaining: > 95%
Compound 4: a limit, no number (the forecaster's own chance of this, stated with the estimate: 80%); the middle value sits exactly at the limit.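

Going by these compounds alone, no step to compound 4 can be read from compound 3 or from compound 1, as both ends of each pair are limits. The compounds shown leave open whether they differ at all in this assay: the limit of > 95% in this assay, at which 4 of the 4 values shown sit.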